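The source may hold more compounds than are shown below. What is called first, only, known or untested is meant among the compounds shown, and "the series" means these compounds.

Working notes on the series in an assay on isolated protein for inhibition of MAP kinase-activated protein kinase 2 (Homo sapiens), read by mobility shift assay, tested at 30 uM; on this read-out lower numbers stand for less inhibition and higher numbers for more inhibition at the one concentration tested (going by the name of the read-out). Of the compounds shown here, three on a shared core have numbers so far. Compound 1 `Cc1cc2nn(-c3ccccc3)c(N)c2c(=O)[nH]1` gives -4%. Compound 2 `CC(C)(C)c1cc2nn(-c3ccccc3)c(N)c2c(=O)[nH]1` gives 6%. Compound 3 `Nc1c2c(=O)[nH]c(-c3ccccn3)cc2nn1-c1ccccc1` gives 4%. The steps between them are small: a number 10 percentage points higher from compound 1 to compound 2 (within the scatter), a number 8 percentage points higher from compound 1 to compound 3 (within the scatter) and a number 2 percentage points lower from compound 2 to compound 3 (within the scatter). On the numbers shown, compound 3 stands second highest of the three, nearest to compound 2 and furthest from compound 1, but every gap lies within the scatter, so no order among the three is established; all three sit near zero inhibition at the single concentration tested.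

Compound 4 `COc1ccccc1-c1cc2nn(-c3ccccc3)c(N)c2c(=O)[nH]1` is the next compound, differing from compound 3 at one place: 2-methoxyphenyl in place of pyridin-2-yl on an aromatic carbon. Within the data shown here, the steps that bear on this position are those from compound 1 to compound 3 and from compound 2 to compound 3, in which methyl and tert-butyl were exchanged for pyridin-2-yl at the same aromatic carbon; both stayed within the scatter. Among the measured compounds shown here, nothing measured so far suggests that a further exchange of the group at this carbon moves the read-out, so for compound 4 no step beyond the scatter is expected, no change at the digits printed from compound 3 to compound 4 (within the scatter). The estimate for compound 4 is 4%, within a range from -8% to 16%.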

Compound 4, a percentage reported as inhibition, at one concentration (the size of the read-out at that concentration, not a potency): -1%
Estimate against measurement, compound 4: 5 percentage points above; measured number inside the range.
By their numbers in this assay, from the lowest: compounds 1, 4, 3 and 2 (each within the scatter of the next).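

In this assay, 2-methoxyphenyl in place of pyridin-2-yl on the aromatic carbon next to the ring nitrogen gives a number 5 percentage points lower from compound 3 to compound 4 (within the scatter), so replacing the aromatic ring with 1 hetero atom by one of carbon only, with a methoxy group on it, produces no step beyond the scatter. The same group gives a number 7 percentage points lower from compound 2 to compound 4 (within the scatter) and a number 3 percentage points higher from compound 1 to compound 4 (within the scatter) when set against the two alkyl groups, which extends the earlier picture to a fourth group at this carbon: methyl, tert-butyl, pyridin-2-yl and 2-methoxyphenyl cannot be told apart on this read-out. No supporting data bear on why the read-out does not separate these groups.

On these data alone, whether any group at this carbon can lift the read-out clear of the scatter remains open, for instance an amine, a carboxylic acid or a longer alkyl chain. All four compounds also share the phenyl and amino groups of the core, so what an exchange of either would do is equally unknown.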